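Halogen swap on the isatin-type core, two positions

The source may report more compounds than this note shows. Statements on the series, on what has been measured and on what is new or still open speak of the compounds shown alone.

Compound 1 `O=C1C(=O)N(CCCNc2ccnc3cc(Cl)ccc23)c2cccc(Cl)c21` carries a chloro on the core; in an ADME assay on MCF-10A cells (Homo sapiens) for antiproliferative activity, read by sulforhodamine B assay, with a stated time of 48 h (a lower number here means a stronger inhibitor of growth, a higher number a weaker inhibitor of growth), compound 1 gives 84800 nM. Compound 2 `O=C1C(=O)N(CCCNc2ccnc3cc(Cl)ccc23)c2cccc(Br)c21` differs from it in one place, (bromo in place of chloro on an aromatic carbon), and in this assay compound 2 gives 20800 nM. The step, a 4.1-fold lower number from compound 1 to compound 2 (0.61 log units; beyond the scatter), is modest but beyond the scatter. Compound 3 `O=C1C(=O)N(CCCNc2ccnc3cc(Cl)ccc23)c2cc(Cl)ccc21` keeps chloro but carries it on a different position of the core; the difference between the core of compound 1 and the core of compound 3 is not broken down here. In this assay compound 3 gives 6880 nM, the lowest of the three numbers, with compound 2 nearest and compound 1 furthest, both gaps beyond the scatter.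

Compound 4 `O=C1C(=O)N(CCCNc2ccnc3cc(Cl)ccc23)c2cc(Br)ccc21` is not yet measured. It differs from compound 3 by bromo in place of chloro on an aromatic carbon. This is the same kind of change as that from compound 1 to compound 2, but not the same: there the site was ortho to a fused ring and meta to a fused ring, here it is meta to a fused ring and para to a fused ring. One step cannot be carried over blindly. Within the data shown here, the single measured swap, a 4.1-fold lower number from compound 1 to compound 2 (0.61 log units; beyond the scatter), sat at another position. For compound 4 a somewhat smaller step is therefore expected, a 2.5-fold lower number from compound 3 to compound 4 (0.39 log units; beyond the scatter). The estimate for compound 4 in this assay is 2800 nM, between 1100 nM and 7000 nM.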

Compound 4, concentration for 50% growth inhibition: 19900 nM
Compound 4: middle estimate off by 7.1-fold (0.85 log units), on the low side, and the stated range ends below it.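

On the core of compound 3, bromo in place of chloro gives a 2.9-fold higher number from compound 3 to compound 4 (0.46 log units; beyond the scatter) in this assay, so the swap that lowered the number on the core of compound 1 raises it here, and the two steps differ clearly in direction and size: the same change on two cores in this assay, a 4.1-fold lower number (0.61 log units; beyond the scatter) from compound 1 to compound 2 and a 2.9-fold higher number (0.46 log units; beyond the scatter) from compound 3 to compound 4, 12-fold (1.07 log units) apart, beyond the scatter of two such steps In this series, then, neither the direction nor the size of this halogen swap carries from one core to the other, and a step read on one core gives no safe guide to the same change on the other. Among these compounds, the result does not show why the two steps part, and with only one pair per core it does not show whether either step is typical of its core or would be repeated in another cell assay.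

Still open, on these data alone, is whether a fluoro or an iodo on an aromatic carbon of either core would follow the chloro-to-bromo trend seen on that core, or whether a methoxy or a nitrile there would behave differently again. Also open, as far as these compounds go, is whether the opposite steps would persist with a longer chain joining the core to the rest of the molecule.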